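From 4-methoxyphenyl to cyclohexyl on compound 2

This account rests on a few compounds, and the source may have more. Where it says the series, first, only, none or still open, it means among the compounds named here.

Compound 1 `COc1ccc(-c2cc(NNC(=O)Nc3cc(Cl)nc(Cl)c3)nc3c2cnn3C)cc1`: 12300 nM
Compound 2 `COc1ccc(-c2cc(NNC(=O)Nc3cc(Cl)nc(Cl)c3)nc3c2c(C)nn3C)cc1`: 82300 nM
Compound 3 `COc1cc(NC(=O)NNc2cc(-c3ccc(F)cc3)c3cnn(C)c3n2)cc(OC)c1OC`: 45300 nM

All three were tested in a functional assay on HCT-116 cells (Homo sapiens) for cytotoxicity, read by MTT assay, with a stated time of 48 h, in the presence of a further agent that is not named here; on this read-out lower numbers stand for an effect already at smaller amounts and higher numbers for an effect only at larger amounts of compound. Compound 2 gives 82300 nM, which lies within the usual scatter of compound 3 at 45300 nM. Among the measured compounds shown here, the one measured step that reaches it is a 6.7-fold higher number from compound 1 to compound 2 (0.83 log units; beyond the scatter), with methyl in place of hydrogen on an aromatic carbon.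

Compound 4 `Cc1nn(C)c2nc(NNC(=O)Nc3cc(Cl)nc(Cl)c3)cc(C3CCCCC3)c12` keeps that methyl and carries a different change: cyclohexyl in place of 4-methoxyphenyl on an aromatic carbon. This puts cyclohexyl in place of 4-methoxyphenyl on an aromatic carbon. The methyl step concerns another place, so it says little here, and compound 3 differs from compound 2 in more than one place. For the measured compounds named here, no measured step tests this swap, so the expectation stays close to compound 2 at 82300 nM, with no firm direction and nothing beyond the scatter. The expected change is a 1.2-fold lower number from compound 2 to compound 4 (0.07 log units; within the scatter). Compound 4 is estimated at 70000 nM, with an expected range of 25000 nM to 180000 nM.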

Compound 4, half-maximal effective concentration: 38000 nM
Estimate against measurement, compound 4: 1.8-fold (0.27 log units) above, within the range that was stated.
By their numbers in this assay, from the lowest: compound 1; then compounds 4, 3 and 2 (each within the scatter of the next, the first and the last beyond it).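

In this assay, putting cyclohexyl in place of 4-methoxyphenyl gives a 2.2-fold lower number from compound 2 to compound 4 (0.34 log units; beyond the scatter), a modest change that only just clears the usual scatter. Among the compounds shown here, this is the first measured change at this position, opposite the ring nitrogen, and it shows that on the core of compound 2 an aromatic ring is not required there: a non-aromatic carbon ring without the hydrogen-bond acceptor does not raise the number. Nothing available explains why the number moves in this direction.

As far as these compounds go, compound 4 keeps the methyl of compound 2, so it remains open whether the same swap would behave alike on the core of compound 1, which lacks that methyl. The compounds shown also leave open how an open chain such as butyl or a ring carrying an amine, such as piperidine, would read at this position.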